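Replacing the indolyl group of compound 2 with a dichlorophenyl group

The source may report more compounds than this note shows. Statements on the series, on what has been measured and on what is new or still open speak of the compounds shown alone.

Compound 2 `Cc1ccc(S/C(=C/c2c[nH]c3ccccc23)C(=O)c2ccc(Cl)cc2)cc1` is one of three compounds tested in a functional assay on DU-145 cells (Homo sapiens) for inhibition, read by trypan blue exclusion, with a stated time of 96 h (on this read-out higher numbers stand for weaker inhibition of growth and lower numbers for stronger inhibition of growth), where compound 2 gives 10000 nM. Compound 1 `Cc1ccc(S/C(=C/c2c[nH]c3ccccc23)C(=O)c2ccc(Br)cc2)cc1` gives 10000 nM in this assay, and the step of no change at the digits printed from compound 1 to compound 2 (within the scatter) sits within the scatter, so the two stand level and together give the highest numbers of the three. Compound 3 `O=C(/C(=C\c1c[nH]c2ccccc12)SCc1ccc(F)cc1)c1ccc(Cl)cc1` gives 1000 nM in this assay; the step of a 10-fold lower number from compound 2 to compound 3 (1.00 log units; beyond the scatter) is the only one beyond the scatter in the set.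

Compound 4 `Cc1ccc(S/C(=C/c2ccc(Cl)cc2Cl)C(=O)c2ccc(Cl)cc2)cc1` differs from compound 2 in the change (2,4-dichlorophenyl in place of 1H-indol-3-yl on a double-bonded chain carbon bound to a double-bonded chain carbon). Neither measured step bears directly on it: the step from compound 1 to compound 2 alters only a halogen on an aromatic carbon, and the step from compound 2 to compound 3 alters only the group on the sulfur, while the group on the double-bonded chain carbon is kept in all three measured compounds. The data therefore give no measured guide to this change, and the expectation is that compound 4 stays near compound 2, with the step of no change at the digits printed from compound 2 to compound 4 (within the scatter) estimated to lie within the scatter. In this assay compound 4 is estimated at 10000 nM, with a range from 3000 nM to 30000 nM.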

Compound 4, concentration for 50% growth inhibition: 10000 nM
Estimate against measurement, compound 4: no gap at the digits printed; measured number inside the range.
By their numbers in this assay, from the lowest: compound 3; then compounds 1, 2 and 4 (each within the scatter of the next).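

In this assay, within the data shown here, replacing 1H-indol-3-yl with 2,4-dichlorophenyl on the double-bonded chain carbon gives no change at the digits printed from compound 2 to compound 4 (within the scatter), the first reading at a position held constant across compounds 1, 2 and 3. With the rest of compound 2 kept, the number therefore does not depend on the five-membered aromatic ring or on the hydrogen-bond donor counted for 1H-indol-3-yl, neither of which is present in 2,4-dichlorophenyl. Nothing at hand accounts for this level reading, and the two groups can be called equivalent here only for this one pair, at a number as high as any in the set.

Open, as far as these compounds go, is whether the same exchange stays level when the sulfur carries the 4-fluorobenzyl group of compound 3, which gives 1000 nM, since a level step at the high end of the set need not carry over to a compound with a lower number. Also open, from the compounds shown here alone, is what a carboxylic acid, an amine or a longer alkyl chain would give on the double-bonded chain carbon in place of either aromatic group.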